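Fluoro in place of methoxy on an aromatic carbon

This account rests on a few compounds, and the source may have more. Where it says the series, first, only, none or still open, it means among the compounds named here.

Going by the values given here, compound 2 `COc1ccc(C(=O)c2ccc3c(ccn3S(=O)(=O)c3cccc(/C=C/C(=O)NO)c3)c2)cc1` gives 751 nM in an assay on isolated protein for inhibition of protein deacetylase HDAC6 (Homo sapiens) (a higher number here means a weaker inhibitor, a lower number a stronger inhibitor), the larger of the two numbers measured so far, although its only neighbour, compound 1 `COc1cc(C(=O)c2ccc3c(ccn3S(=O)(=O)c3cccc(/C=C/C(=O)NO)c3)c2)cc(OC)c1OC`, stands close by: in this assay compound 1 gives 562 nM, and the step of a 1.3-fold higher number from compound 1 to compound 2 (0.13 log units; within the scatter) lies within the scatter. Compound 3 `O=C(/C=C/c1cccc(S(=O)(=O)n2ccc3cc(C(=O)c4ccc(F)cc4)ccc32)c1)NO` differs from compound 2 by fluoro in place of methoxy on an aromatic carbon. Among the compounds with values here, the single measured step bears on this change only loosely, as it exchanged one methoxy-bearing phenyl for another on the carbonyl carbon rather than trading a methoxy for a fluoro, and it was small. With the two measured compounds this close together, the new exchange is expected to move the number little if at all. Compound 3 is therefore estimated at 800 nM, with a range from 350 nM to 1800 nM. The expected step of a 1.1-fold higher number from compound 2 to compound 3 (0.03 log units; within the scatter) is judged to fall within the scatter.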

Compound 3, half-maximal inhibitory concentration: 1420 nM
Compound 3: middle estimate off by 1.8-fold (0.25 log units), on the low side; the range from low to high includes it.
By their numbers in this assay, from the lowest: compounds 1, 2 and 3 (each within the scatter of the next, the first and the last beyond it).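

In this assay, the exchange of methoxy for fluoro on this aromatic carbon, para to a large group, gives a 1.9-fold higher number from compound 2 to compound 3 (0.28 log units; within the scatter) and so stays within the scatter. Placing 4-fluorophenyl instead of 3,4,5-trimethoxyphenyl on the carbonyl carbon gives a 2.5-fold higher number from compound 1 to compound 3 (0.40 log units; beyond the scatter) and is the only step here beyond the scatter, although a modest one. The group on the carbonyl carbon can therefore move the number measurably, while the 4-methoxyphenyl group lies within the scatter of both other groups. Nothing available here accounts for these differences. Still open, from the compounds shown here alone, is how an amine, a carboxylic acid or a chloro at this same place would compare with fluoro and methoxy. Also open, going by these compounds, is whether an unsubstituted phenyl on the carbonyl carbon would fall within the scatter of compound 3.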